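Acetylating the hydroxy group of compound 2

The source may report more compounds than this note shows. Statements on the series, on what has been measured and on what is new or still open speak of the compounds shown alone.

Within the data shown here, in an ADME assay on ECV-304 cells (Homo sapiens) for cytotoxicity, read by MTT assay, with a stated time of 72 h (a lower number here means a stronger inhibitor, a higher number a weaker inhibitor), compound 1 (`COc1ccc(C2=C(c3cc(OC)c(OC)c(OC)c3)C(=O)C(OC(C)=O)C2)cc1`) gives 18 ug/mL and compound 2 (`COc1ccc(C2=C(c3cc(OC)c(OC)c(OC)c3)C(=O)C(O)C2)cc1Cl`) gives 20 ug/mL (two values within the scatter of each other), so compound 2 stands level with the only other measured compound. Compound 3 (`COc1ccc(C2=C(c3cc(OC)c(OC)c(OC)c3)C(=O)C(OC(C)=O)C2)cc1Cl`) differs from compound 2 by acetyl in place of hydrogen on an oxygen on a saturated carbon (hydroxy to acetoxy, acetyl in place of hydrogen on an oxygen on a saturated carbon). Among the measured compounds shown here, no measured step isolates this change. Compound 1 also carries the acetoxy group and gives 18 ug/mL in this assay (no clear separation from compound 2). The expected change is a 1.1-fold lower number from compound 2 to compound 3 (0.02 log units; within the scatter) and is not expected to exceed the scatter in either direction. Compound 3 is estimated at 19 ug/mL (expected range 8 ug/mL to 42 ug/mL).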

Compound 3, half-maximal inhibitory concentration: 3.5 ug/mL
Compound 3: the middle estimate sits 5.4-fold (0.73 log units) above what was measured; measured number below the stated range.
By their numbers in this assay, from the lowest: compound 3; then compounds 1 and 2 (each within the scatter of the next).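

In this assay the change from hydroxy to acetoxy gives a 5.7-fold lower number from compound 2 to compound 3 (0.76 log units; beyond the scatter) and chloro in place of hydrogen on an aromatic carbon gives a 5.1-fold lower number from compound 1 to compound 3 (0.71 log units; beyond the scatter) with both groups present in compound 3. Each step lies beyond the scatter, so the acetoxy group makes a difference with the chloro group present, and the chloro group makes one with the acetoxy group present. Nothing available explains how either step arises.

From the compounds shown here alone, what the hydroxy-to-acetoxy change does without the chloro group stays open. So does whether a propionyloxy or methoxy group on that oxygen, or a bromo or fluoro group in place of chloro, would give a similar step.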